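Ester Lengthening on the Shared Core: Compound 3 Expected

The source may hold more compounds than are shown below. What is called first, only, known or untested is meant among the compounds shown, and "the series" means these compounds.

Compound 1 `C/C=C1/[C@H](O[C@@H]2O[C@H](CO)[C@@H](O)[C@H](O)[C@H]2O)OC=C(C(=O)OC)[C@H]1CC(=O)NCCC` and compound 2 `C/C=C1/[C@H](O[C@@H]2O[C@H](CO)[C@@H](O)[C@H](O)[C@H]2O)OC=C(C(=O)OC)[C@H]1CC(=O)OC` share one core and differ only at a carbonyl carbon. In a functional assay on SK-BR-3 cells (Homo sapiens) for antiproliferative activity, read by MTT assay, with a stated time of 72 h (on this read-out lower numbers stand for stronger inhibition and higher numbers for weaker inhibition), compound 1 gives > 20000 nM, which is a limit of the assay rather than a number. In this assay compound 2 gives > 15000 nM, again a limit of the assay. The step that the two limits leave unreadable from compound 1 to compound 2 is therefore unreadable because the limit of > 15000 nM in this assay, at which 1 of the 2 values shown sits, and the limit of > 20000 nM in this assay, at which 1 of the 2 values shown sits, both sit at the limits. Going by the values given here, compound 2 thus stands only at a limit in this assay, and the one further value shown is likewise a limit.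

Compound 3 `C/C=C1/[C@H](O[C@@H]2O[C@H](CO)[C@@H](O)[C@H](O)[C@H]2O)OC=C(C(=O)OC)[C@H]1CC(=O)OCCc1ccc(OC)cc1` arises from compound 2 through (4-methoxybenzyl in place of hydrogen on a saturated chain carbon bound to an oxygen next to a carbonyl group). Among the compounds with values here, the only measured step, the one from compound 1 to compound 2, bears on this change solely in that both ends are limits, so its size is not known and no direction can be taken from it. Compound 3 is therefore expected to remain weak in this assay, with a step estimated as a number no higher from compound 2 to compound 3 (the limit leaves the size open). The estimate for compound 3 is 15000 nM, within a range from 3000 nM to 60000 nM.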

Compound 3, half-maximal inhibitory concentration: > 20000 nM
Compound 3: only a limit was reported; the forecaster's own chance of this, stated with the estimate: 60%; at least 1.3-fold (0.12 log units) between middle value and limit.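

In this assay compound 3 gives > 20000 nM, which is a limit of the assay and not a number. Going by these compounds alone, no step from compound 1 or compound 2 to compound 3 can be read. The compounds shown leave open how far each lies past its limit, and whether the methoxy, propylamino or 2-(4-methoxyphenyl)ethoxy group on the carbonyl carbon makes any difference in this assay.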